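The source may report more compounds than this note shows. Statements on the series, on what has been measured and on what is new or still open speak of the compounds shown alone.

Within the data shown here, compound 2 `CN1CCN(S(=O)(=O)NC(=O)c2ccc(N3CCN(CC4=C(c5ccc(Cl)cc5)CCC(C)(C)C4)CC3)cc2)CC1` gives the lower of the two numbers so far in an assay on isolated protein for displacement of a labelled ligand from Apoptosis regulator Bcl-2 (Homo sapiens), read by fluorescence polarization (on this read-out higher numbers stand for weaker inhibition and lower numbers for stronger inhibition), at 168 nM; compound 1 `CC1(C)CCC(c2ccc(Cl)cc2)=C(CN2CCN(c3ccc(C(=O)NS(C)(=O)=O)cc3)CC2)C1` gives 495 nM. Among the measured compounds shown here, the one step already known, a 2.9-fold lower number from compound 1 to compound 2 (0.47 log units; beyond the scatter), swapped a methyl for 4-methylpiperazin-1-yl on the sulfonyl sulfur. Compound 3 `Cn1ccc(S(=O)(=O)NC(=O)c2ccc(N3CCN(CC4=C(c5ccc(Cl)cc5)CCC(C)(C)C4)CC3)cc2)n1` changes that same position again: 1-methyl-1H-pyrazol-3-yl in place of 4-methylpiperazin-1-yl on a sulfonyl sulfur. For the measured compounds named here, nothing measured speaks to an aromatic ring at this site, so the single earlier step offers only loose guidance, and the expectation is for little change beyond the scatter, a 1.2-fold higher number from compound 2 to compound 3 (0.08 log units; within the scatter). Compound 3 is therefore estimated at 200 nM, with a range of 60 nM to 650 nM.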

Compound 3, half-maximal inhibitory concentration: 67.4 nM
Beside the measured number, compound 3's estimate is 3.0-fold (0.47 log units) above it; the measured number falls inside the stated range.
By their numbers in this assay, from the lowest: compound 3; then compound 2; then compound 1.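

With a 2.5-fold lower number from compound 2 to compound 3 (0.40 log units; beyond the scatter) the aromatic 1-methyl-1H-pyrazol-3-yl outdoes the non-aromatic 4-methylpiperazin-1-yl, so the sulfonyl sulfur can carry an aromatic ring and the number still falls. Set against the methyl group, the same ring gives a 7.3-fold lower number from compound 1 to compound 3 (0.87 log units; beyond the scatter) and this is the widest gap among the three compounds. No measurement shown explains the gain. Still open, as far as these compounds go, is whether any aromatic ring would serve here or whether the ring nitrogens matter, a question that a plain phenyl ring on the sulfonyl sulfur would address.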